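This account rests on a few compounds, and the source may have more. Where it says the series, first, only, none or still open, it means among the compounds named here.

Measured so far in an ADME assay on Vero cells (Chlorocebus sabaeus) for cytotoxicity, read by microscopy; on this read-out higher numbers stand for lower toxicity in this test and lower numbers for higher toxicity in this test:
- compound 1 `CSc1nc(NCCCCNc2ccnc3cc(Cl)ccc23)c(C#N)c(-c2ccccc2)n1` gives 20000 nM
- compound 2 `CSc1nc(-c2ccc([N+](=O)[O-])cc2)c(C#N)c(N2CCN(c3ccnc4cc(Cl)ccc34)CC2)n1` gives 100000 nM

Compound 1 stands at the lowest of the two numbers, that is, it is the more cytotoxic of the pair in this assay. Compound 2 reads a higher number, and the gap between compound 1 and compound 2 lies beyond the scatter of repeated measurements; the two compounds differ in several places at once, so the numbers alone are what can be said of them.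

Compound 3 `COc1cc(-c2nc(SC)nc(NCCCCNc3ccnc4cc(Cl)ccc34)c2C#N)cc(OC)c1OC` is the next compound to be measured in this assay. It departs from compound 1 in one place:

3,4,5-trimethoxyphenyl in place of phenyl on an aromatic carbon

For the measured compounds named here, no pair of measured compounds that differ in one place is available in this set, so there is no measured step to lean on. The expectation for compound 3 is a small step, not beyond the scatter, in either direction: no change at the digits printed from compound 1 to compound 3 (within the scatter) is what the estimate means. Compound 3 is therefore expected to give about 20000 nM in this assay, within a range from 6000 nM to 70000 nM.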

Compound 3, minimum cytotoxic concentration: 4000 nM
For compound 3 the middle estimate is 5.0-fold (0.70 log units) above the measured one; measured number below the stated range.
By their numbers in this assay, from the lowest: compound 3; then compound 1; then compound 2.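

In this assay the aromatic carbon ortho to a cyano group proves sensitive to the group it carries: 3,4,5-trimethoxyphenyl in place of phenyl gives a 5.0-fold lower number from compound 1 to compound 3 (0.70 log units; beyond the scatter) and so moves the read-out towards higher toxicity in this test. For the compounds shown here, compound 1 and compound 2 differ in several places at once, so this is the first step that isolates one place, and it shows that a change at this position alone can shift the read-out beyond the scatter. No measurement at hand bears on the origin of this step, which stands here as an observation only.

The compounds shown leave open whether the step follows from the full 3,4,5-trimethoxyphenyl group or would also appear with a simpler group at this position, such as a methoxyphenyl, a fluorophenyl, a pyridyl or an aminophenyl group. Also open, on these data alone, is whether the same replacement would give a comparable step on a compound with the linking part of compound 2 in place of the butane-diamine chain of compound 1.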